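Benzyl ester to methyl ketone on the exocyclic chain

The compounds below may be only part of what the source reports. "The series", "measured", "known", "first", "only" and "open" are said of these compounds alone.

Working notes on a small series sharing one bicyclic core. Compound 1 `CC1(C)S[C@@H]2/C(=C\C(=O)OCc3ccccc3)C(=O)N2[C@H]1C(=O)OC(c1ccccc1)c1ccccc1` is measured in a functional assay on OE19 cells (Homo sapiens) for cytotoxicity, read by MTT assay, with a stated time of 48 h (a higher number here means a weaker inhibitor, a lower number a stronger inhibitor), at 8200 nM, the lowest number among the three measured compounds. Compound 2 `CC1(C)S[C@@H]2/C(=C\C(=O)OC(c3ccccc3)c3ccccc3)C(=O)N2[C@H]1C(=O)OC(c1ccccc1)c1ccccc1` gives 21600 nM in this assay, and the step of a 2.6-fold higher number from compound 1 to compound 2 (0.42 log units; beyond the scatter) is modest but beyond the scatter. Compound 3 `CC1(C)[C@H](C(=O)OC(c2ccccc2)c2ccccc2)N2C(=O)/C(=C/C(=O)c3ccccc3)[C@H]2S1(=O)=O` differs from compound 1 in several places. In this assay compound 3 gives 53100 nM. Among the measured compounds shown here, the two values of compound 3 and compound 1 show the widest gap in the set, but no single-change step connects them.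

Compound 4 `CC(=O)/C=C1/C(=O)N2[C@@H]1SC(C)(C)[C@@H]2C(=O)OC(c1ccccc1)c1ccccc1` is not yet measured. It differs from compound 1 as follows: methyl in place of benzyloxy on a carbonyl carbon. For the measured compounds named here, no measured step matches this change: the one single-change step in the set adds a phenyl at a different position, and compound 3 carries other changes alongside its ketone. The step of a 1.2-fold higher number from compound 1 to compound 4 (0.09 log units; within the scatter) is therefore expected to be small, with no clear direction beyond the scatter. Compound 4 is estimated at 10000 nM in this assay, within the range 3000 nM to 35000 nM.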

Compound 4, half-maximal inhibitory concentration: 51900 nM
Beside the measured number, compound 4's estimate is 5.2-fold (0.72 log units) below it; measured number above the stated range.
By their numbers in this assay, from the lowest: compound 1; then compound 2; then compounds 4 and 3 (each within the scatter of the next).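

Methyl in place of benzyloxy on a carbonyl carbon gives a 6.3-fold higher number from compound 1 to compound 4 (0.80 log units; beyond the scatter) in this assay so the benzyloxycarbonyl to acetyl change is not neutral at this position. Among the compounds shown here, until now the only single-change reading on this chain was the added phenyl of compound 2; the new step shows that removing the benzyloxy group also raises the number, so both single changes read from compound 1 run the same way. No measurement at hand accounts for this step.

The compounds shown do not separate the loss of the aromatic ring from the replacement of the ester oxygen. A methyl ester or a benzyl ketone at this carbonyl carbon on the unchanged core would bear on that question.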